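Thienopyrimidine aryl ethers: pyrrolidine to piperidine on the pyrimidine

The source may report more compounds than this note shows. Statements on the series, on what has been measured and on what is new or still open speak of the compounds shown alone.

Measured so far:
compound 1, `CN(C)c1ccc(C(=O)Nc2ccc(Oc3ncnc4ccsc34)cc2)cc1`, 10.4%
compound 2, `CN(c1ccc(Oc2ncnc3ccsc23)cc1)c1nccc(N2CCCC2)n1`, 38%

Both compounds share the aryl ether core and were tested in a functional assay on MDA-MB-231 cells (Homo sapiens) for inhibition, read by MTT assay, with a stated time of 72 h, tested at 20 uM; on this read-out lower numbers stand for less inhibition and higher numbers for more inhibition at the one concentration tested (going by the name of the read-out). Compound 1 gives 10.4%, compound 2 gives 38%. Compound 2 therefore holds the higher of the two numbers, and its gap to compound 1 lies beyond the usual scatter of the read-out. Among the compounds with values here, the two compounds differ in several places at once, so no single step between them can be set down; only the two values themselves are available.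

The next compound, compound 3, `CN(c1ccc(Oc2ncnc3ccsc23)cc1)c1nccc(N2CCCCC2)n1`, is a close relative of compound 2. The change is piperidin-1-yl in place of pyrrolidin-1-yl on an aromatic carbon. The five-membered ring grows to a six-membered ring at the same aromatic carbon, with the hydrogen-bond donor and acceptor count unchanged. Nothing measured in this series bears on such a ring expansion, so the expectation rests on compound 2 alone. The step is expected to be small, no change at the digits printed from compound 2 to compound 3 (within the scatter), within the scatter in either direction. Compound 3 is thus estimated at 38%, with a range from 22% to 55%.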

Compound 3, a percentage reported as inhibition, at one concentration (the size of the read-out at that concentration, not a potency): 49.7%
Compound 3: middle estimate off by 11.7 percentage points, on the low side; the range from low to high includes it.
By their numbers in this assay, from the lowest: compound 1; then compound 2; then compound 3.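

Piperidin-1-yl in place of pyrrolidin-1-yl on the aromatic carbon next to the ring nitrogen gives the first step in this series that can be read at a single place: in this assay it is a number 11.7 percentage points higher from compound 2 to compound 3 (beyond the scatter), and it is the only such step available. The read-out at this position therefore responds to the size of the saturated ring alone, since the group that leaves and the group that enters have the same counts of hydrogen-bond donors and acceptors and neither carries a net charge, and compound 3 now holds the highest number of the three compounds. No measurement on hand accounts for this step, so the result stands as an observation about these two groups only.

One step cannot show whether the number keeps moving with ring size, or whether the ring matters at all compared with an open-chain amine, and azepan-1-yl, morpholin-4-yl and diethylamino at the same aromatic carbon would address these points. Since each number comes from one concentration, the step also leaves open how compound 2 and compound 3 compare in potency.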